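A few compounds are considered here, and "the series" means these few. Any claim that something is new, unique, unknown or untested is made for them only; others in the source may bear on it.

Working notes on the series. Compound 1 `CNc1cccc(-c2cc(=O)c3cc(N4CCCC4)ccc3[nH]2)c1` and compound 2 `CCNc1cccc(-c2cc(=O)c3cc(N4CCCC4)ccc3[nH]2)c1` share one core and differ only in the group on the aromatic nitrogen. In a functional assay on Hep 3B2 cells (Homo sapiens) for cytotoxicity (a higher number here means a weaker inhibitor, a lower number a stronger inhibitor), compound 1 gives 21 nM, and compound 2 gives 20 nM; the step of a 1.1-fold lower number from compound 1 to compound 2 (0.02 log units; within the scatter) lies within the scatter, so the two numbers are not separated. Compound 2 thus stands at one end of two numbers that are indistinguishable.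

Compound 3 `CN(C)c1cccc(-c2cc(=O)c3cc(N4CCCC4)ccc3[nH]2)c1` is the next case: dimethylamino in place of ethylamino on an aromatic carbon. Among the measured compounds shown here, the single measured step, a 1.1-fold lower number from compound 1 to compound 2 (0.02 log units; within the scatter), shows that adding carbon at that nitrogen leaves this assay unmoved, but no measured step removes the hydrogen-bond donor from that nitrogen, so the change is only partly covered. The expectation is therefore no step beyond the scatter, with wider uncertainty than the measured pair. For compound 3 the estimated value in this assay is 25 nM, range 10 nM to 70 nM, meaning an expected step of a 1.3-fold higher number from compound 2 to compound 3 (0.10 log units; within the scatter).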

Compound 3, half-maximal inhibitory concentration: 15 nM
Estimate against measurement, compound 3: 1.7-fold (0.22 log units) above; the range from low to high includes it.
By their numbers in this assay, from the lowest: compounds 3, 2 and 1 (each within the scatter of the next).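

In this assay the exchange of ethylamino, with 1 hydrogen-bond donor, for dimethylamino, with 0 hydrogen-bond donors, gives a 1.3-fold lower number from compound 2 to compound 3 (0.12 log units; within the scatter) and so shows what the earlier pair did not: at this position on the aromatic carbon, losing the donor does not separate the numbers. Putting methyl on the nitrogen of compound 1 gives a 1.4-fold lower number from compound 1 to compound 3 (0.15 log units; within the scatter) and leads to the same reading, so the three compounds remain a single group in this assay. Nothing available bears on why the numbers stay together.

The compounds shown leave open whether a longer chain such as propyl on this nitrogen, or an amide in place of the amine, would give a step beyond the scatter. As far as these compounds go, whether these steps hold on a different core is also open.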